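Pyrrolidin-1-yl in Place of Diisopropylamino on Compound 4

This account rests on a few compounds, and the source may have more. Where it says the series, first, only, none or still open, it means among the compounds named here.

In a functional assay on LM7 cells (Homo sapiens) for antiproliferative activity, read by MTT assay, with a stated time of 72 h (a lower number here means a stronger inhibitor, a higher number a weaker inhibitor), compound 1 `Cc1ccc2c(=O)c(CSC(=S)N(C(C)C)C(C)C)coc2c1` gives 6300 nM, and compound 2 `O=c1c(Cl)c(CSC(=S)N2CCCC2)oc2ccccc12` gives 1900 nM. Compound 3 `CC(C)N(C(=S)SCc1coc2cc(Cl)ccc2c1=O)C(C)C` reaches only the limit of the assay at > 25000 nM. Within the data shown here, the single measured step, an at least 3.9-fold higher number from compound 1 to compound 3 (0.59 log units; beyond the scatter), concerns a different change. Compound 4 `O=c1c(CSC(=S)N2CCCC2)coc2cc(Cl)ccc12` differs from compound 3 in one place: pyrrolidin-1-yl in place of diisopropylamino on a thiocarbonyl carbon. No measured step alters this amine, so nothing shown bears directly on the size or direction of the coming step; compound 2 also carries pyrrolidin-1-yl, but differs from compound 4 elsewhere as well and only shows its own value. For compound 4 the estimate is 15000 nM, within 4000 nM to 50000 nM. This expected step, an at least 1.6-fold lower number from compound 3 to compound 4 (0.22 log units; that floor lies within the scatter), is at most modest and downward.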

Compound 4, half-maximal inhibitory concentration: 2600 nM
The estimate for compound 4 lay 5.8-fold (0.76 log units) above the measured number, outside the stated range (below it).
By their numbers in this assay, from the lowest: compounds 2 and 4 (each within the scatter of the next); then compound 1. At a limit, above all of these: compound 3.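

With the rest of the molecule unchanged, pyrrolidin-1-yl in place of diisopropylamino on a thiocarbonyl carbon gives an at least 9.6-fold lower number from compound 3 to compound 4 (0.98 log units; beyond the scatter), the first measured sign that the amine at this position affects activity in this assay. This size is only a floor, because compound 3 stands at a limit rather than a number: the limit of > 25000 nM in this assay, at which 1 of the 4 values shown sits.

As far as these compounds go, the change rests on this one pair, so whether it would also lower the number for compound 1 remains open. Also open, from the compounds shown here alone, is how piperidin-1-yl, morpholin-4-yl or dimethylamino would compare at this position.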